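Replacing methylsulfanyl with cyano on an aromatic carbon

A few compounds are considered here, and "the series" means these few. Any claim that something is new, unique, unknown or untested is made for them only; others in the source may bear on it.

Within the data shown here, in a functional assay on SK-OV-3 cells (Homo sapiens) for antiproliferative activity, read by MTT assay, with a stated time of 72 h (a higher number here means a weaker inhibitor, a lower number a stronger inhibitor), compound 1 `CSc1cccc(-c2cccc(NC(=O)CCc3cccc4c3B(O)OC4)c2)c1` gives 150 nM and compound 2 `CSc1ccc(-c2cccc(NC(=O)CCc3cccc4c3B(O)OC4)c2)cc1` gives 140 nM, so compound 2 stands level with its only neighbour, within the scatter. Compound 3 `N#Cc1ccc(-c2cccc(NC(=O)CCc3cccc4c3B(O)OC4)c2)cc1` has cyano in place of methylsulfanyl on an aromatic carbon. Among the measured compounds shown here, the one measured step that bears on this, a 1.1-fold lower number from compound 1 to compound 2 (0.03 log units; within the scatter), is small, but both of its compounds keep methylsulfanyl, so replacing that group remains untested. No shift beyond the scatter is therefore expected, and the estimated step is a 1.4-fold higher number from compound 2 to compound 3 (0.15 log units; within the scatter). In this assay, the expected value for compound 3 is 200 nM, with a range of 70 nM to 600 nM.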

Compound 3, half-maximal inhibitory concentration: 340 nM
Beside the measured number, compound 3's estimate is 1.7-fold (0.23 log units) below it, within the range that was stated.
By their numbers in this assay, from the lowest: compounds 2 and 1 (each within the scatter of the next); then compound 3.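

In this assay, the earlier pair showed only that moving methylsulfanyl left the number within the scatter, whereas exchanging that group for cyano gives a shift beyond it (a 2.4-fold higher number from compound 2 to compound 3 (0.39 log units; beyond the scatter)). The step from the other methylsulfanyl compound is of similar size (a 2.3-fold higher number from compound 1 to compound 3 (0.36 log units; beyond the scatter)). This place on the ring therefore responds modestly to which group it carries, but no measurement here gives a cause for the shift. On these data alone, how an amine or a carboxylic acid would fare in the same place stays open, as does whether 3-cyanophenyl would match 4-cyanophenyl.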